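Ring Opening at the Carbonyl: What to Expect for Compound 3

This account rests on a few compounds, and the source may have more. Where it says the series, first, only, none or still open, it means among the compounds named here.

For the measured compounds named here, compound 2 `O=C(c1sc(-c2cccc(F)c2)nc1O)N1CCCCO1` is the only compound in this set that gives a number in an assay on HEK293 cells for inhibition of transient receptor potential cation channel subfamily M member 8 (Homo sapiens), read by FLIPR, with stated times of 5 min and 3 min (on this read-out lower numbers stand for stronger inhibition and higher numbers for weaker inhibition), where compound 2 gives 167 nM. Compound 1 `O=C(c1sc(-c2cccc(F)c2)nc1O)N1CCCOC1` gives > 100000 nM in this assay, which is a limit of the assay and not a number (the limit of > 100000 nM in this assay, at which 1 of the 2 values shown sits). Between them lies the only measured step, an at least 590-fold lower number from compound 1 to compound 2 (2.77 log units; beyond the scatter), so the group on the carbonyl carbon is the one place where change has so far been seen, and that change was large.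

Compound 3 `CCON(C)C(=O)c1sc(-c2cccc(F)c2)nc1O` differs from compound 2 by a group of 5 heavy atoms (3 carbon, 1 nitrogen, 1 oxygen; no ring) in place of a group of 6 heavy atoms (4 carbon, 1 nitrogen, 1 oxygen; one six-membered non-aromatic ring with 2 hetero atoms), on a carbonyl carbon. Going by the values given here, the ring that leaves is the one whose arrival from compound 1 to compound 2 gave the large step, so opening it is expected to matter, most likely toward a higher number, though the single measured step gives no measure of how far an acyclic group falls short of the ring. Compound 3 is therefore expected to give 600 nM in this assay, within 120 nM to 6000 nM. The expected step is a 3.6-fold higher number from compound 2 to compound 3 (0.56 log units; beyond the scatter).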

Compound 3, half-maximal inhibitory concentration: 1680 nM
Compound 3: middle estimate off by 2.8-fold (0.45 log units), on the low side, and the stated range covers the measured number.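

In this assay, a ring on the carbonyl carbon proves not to be required for a measurable number: ethoxy(methyl)amino still brings an at least 59-fold lower number from compound 1 to compound 3 (1.77 log units; beyond the scatter) and so a large step. That step starts from compound 1, whose value is a limit of the assay and not a number: the limit of > 100000 nM in this assay, at which 1 of the 3 values shown sits.

The ring of compound 2 nevertheless keeps a clear lead over the open group, with a 10-fold higher number from compound 2 to compound 3 (1.00 log units; beyond the scatter) on opening, a modest step beside the large one seen between the two rings, so among these three compounds the arrangement of the ring atoms counts for more than the presence of a ring itself.

The compounds shown leave open whether the oxygen in these groups is needed at all, which a piperidine ring or a dimethylamino group on the same carbonyl carbon would test. They also leave open how far the open group can be varied, for instance whether a methoxy group or a longer chain such as propoxy in place of the ethoxy would move the number toward that of compound 2 or away from it.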